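This account rests on a few compounds, and the source may have more. Where it says the series, first, only, none or still open, it means among the compounds named here.

Measured compounds:

compound 1, `N#CCN(Cc1ccccc1)Cc1ccc2ccccc2n1` — 0%
compound 2, `COc1ccc(CN(CC#N)Cc2ccccc2)cc1` — 0%
compound 3, `N#CCCCN(Cc1ccccc1)Cc1ccc2ccccc2c1` — 0%

In an assay on HEK293 cells for binding affinity to Substance-K receptor (Rattus norvegicus), read by FRET, tested at 10 uM (a lower number here means less inhibition, a higher number more inhibition at the concentration tested (going by the name of the read-out)), compound 1 gives 0% and compound 2 gives 0%. Compound 3 gives 0% in this assay, so it stands level with both, and the gaps to compound 1 and to compound 2 are within the scatter; no order among the three can be read from these numbers. Among the compounds with values here, no single-point step between two measured compounds is available in this set.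

The next compound, compound 4, `O=C(CN(Cc1ccccc1)Cc1ccc2ccccc2c1)OCCO`, is not yet measured in this assay. It differs from compound 3 by (2-hydroxyethoxy)carbonyl in place of 2-cyanoethyl on a saturated chain carbon bound to an amine nitrogen. Since nothing in the measured set has moved off the floor, there is no ground for expecting this change to do so either; the expected step of a number 2 percentage points higher from compound 3 to compound 4 (within the scatter) is none beyond the scatter. Compound 4 is estimated at 2% in this assay, in a range from -8% to 12%.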

Compound 4, a percentage reported as inhibition, at one concentration (the size of the read-out at that concentration, not a potency): 0%
Beside the measured number, compound 4's estimate is 2 percentage points above it, within the range that was stated.
By their numbers in this assay, from the lowest: compounds 1, 2, 3 and 4 (each within the scatter of the next).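

In this assay the series now has its first step at a single place, on a saturated chain carbon bound to an amine nitrogen: no change at the digits printed from compound 3 to compound 4 (within the scatter) for (2-hydroxyethoxy)carbonyl in place of 2-cyanoethyl. The nitrile leaves and a carbonyl and a hydroxyl enter, and the read-out stays at the level shared by all four compounds, so this exchange of groups at this position does not separate the two compounds. Nothing available explains this result.

From the compounds shown here alone, with all values at one level, it remains open whether the position is insensitive to change or whether the shared core gives no read-out at the concentration tested. Also open, going by these compounds, is whether a carboxylic acid, an amine or a longer chain at this place would give a different reading.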